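The source may hold more compounds than are shown below. What is called first, only, known or untested is meant among the compounds shown, and "the series" means these compounds.

Compound 1 `O=C(NCCCCc1ccccc1)c1cccc(C2SCC(=O)N2c2cccc(-c3c[nH]nn3)c2)c1` gives 226 mL.min-1.g-1.
Compound 2 `COc1ccccc1N1C(=O)C(C)SC1c1cccc(C(=O)NCCCCc2ccccc2)c1` gives 1170 mL.min-1.g-1.
Compound 3 `C#Cc1cc(C(=O)NCCCCc2ccccc2)cc(C2SCC(=O)N2c2ccccc2OC)c1` gives 1750 mL.min-1.g-1.

All three numbers come from an ADME assay on microsomes from liver (Canis lupus familiaris) for metabolic stability, read by LC-MS, using NADPH, with a stated time of 10 min, tested at 0.1 uM; a lower number here means slower removal, a higher number faster removal of the compound. Compound 1 stands lowest of the three; compound 2 lies beyond the usual scatter above it, and compound 3 further still. Compound 4 `O=C(NCCCCc1ccccc1)c1cccc(C2SCC(=O)N2c2ccc(C3CC3)cc2)c1` has not yet been measured. Relative to compound 1 it carries a group of 9 heavy atoms (9 carbon; one three-membered non-aromatic ring of carbon only, one six-membered aromatic ring of carbon only) in place of a group of 11 heavy atoms (8 carbon, 3 nitrogen; one five-membered aromatic ring with 3 hetero atoms, one six-membered aromatic ring of carbon only), on an amide-type nitrogen in a ring. Within the data shown here, no measured pair isolates this change on its own. Compound 2 and compound 3, which also carry something other than the departing group on the amide-type nitrogen in the ring, both give numbers well above compound 1, so a rise beyond the scatter is expected, though its size is uncertain. Compound 4 is expected to give 800 mL.min-1.g-1 in this assay, with a likely range from 300 mL.min-1.g-1 to 2000 mL.min-1.g-1. That expectation corresponds to an estimated step of a 3.5-fold higher number from compound 1 to compound 4 (0.55 log units; beyond the scatter).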

Compound 4, intrinsic clearance in microsomes: 1080 mL.min-1.g-1
For compound 4 the middle estimate is 1.4-fold (0.13 log units) below the measured one, and the stated range covers the measured number.
By their numbers in this assay, from the lowest: compound 1; then compounds 4, 2 and 3 (each within the scatter of the next).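

Measured in this assay with only the group on the amide-type nitrogen in a ring changed, 4-cyclopropylphenyl gives a 4.8-fold higher number from compound 1 to compound 4 (0.68 log units; beyond the scatter) and so shows that this position alone can shift the number beyond the scatter. The departing group has a hydrogen-bond donor and acceptors, and the entering group has none, but this single swap cannot separate those features from the rest of the change. Nothing measured here gives a cause for the step.

As far as these compounds go, it remains open whether the five-membered aromatic ring itself matters. A plain phenyl, or a phenyl bearing an amine or a carboxylic acid, on the same nitrogen would help to settle this.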